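Swapping the amino acid arm of compound 1

The source may report more compounds than this note shows. Statements on the series, on what has been measured and on what is new or still open speak of the compounds shown alone.

In a functional assay on HepG2 cells (Homo sapiens) for inhibition, read by MTT assay, with a stated time of 3 days (a lower number here means a stronger inhibitor, a higher number a weaker inhibitor), compound 1 (`COc1cc(-c2nc3ccccc3s2)ccc1OCC(=O)NNC(=O)CN[C@@H](CCSC)C(=O)O`) gives 3780 nM and compound 2 (`COc1cc(-c2nc3ccccc3s2)ccc1OCC(=O)NNC(=O)CNC(=N)NCCC[C@H](N[N+](=O)[O-])C(=O)O`) gives 3490 nM so the two stand level, within the usual scatter of each other. Compound 3 (`CCOC(=O)[C@H](CS)N(CC(=O)NNC(=O)COc1ccc(-c2nc3ccccc3s2)cc1OC)C(C)=O`) differs from compound 1 by one swap (acetyl(1-(ethoxycarbonyl)-2-sulfanylethyl)amino in place of (1-carboxy-3-(methylsulfanyl)propyl)amino on a saturated chain carbon bound to a carbonyl carbon) with acetyl(1-(ethoxycarbonyl)-2-sulfanylethyl)amino in place of (1-carboxy-3-(methylsulfanyl)propyl)amino on a saturated chain carbon bound to a carbonyl carbon. Going by the values given here, no measured pair shows what such a swap does, so no change beyond the scatter is expected. The expected step is a 1.3-fold lower number from compound 1 to compound 3 (0.10 log units; within the scatter) as a rough estimate. For compound 3 the estimated value is 3000 nM with an expected range of 1000 nM to 9000 nM overall.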

Compound 3, half-maximal inhibitory concentration: 3010 nM
The estimate for compound 3 lay 1.0-fold (0.00 log units) below the measured number, and the stated range covers the measured number.
By their numbers in this assay, from the lowest: compounds 3, 2 and 1 (each within the scatter of the next).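

In this assay the swap gives a 1.3-fold lower number from compound 1 to compound 3 (0.10 log units; within the scatter), so this place on a saturated chain carbon bound to a carbonyl carbon accepts a quite different arm without a change that stands out from the scatter. Compound 3 carries no free carboxy group, an ethyl ester and an acetyl on the nitrogen, yet its number stays level with that of compound 1. Nothing measured here explains why the level holds. The ester, acetyl and sulfanyl parts enter together, so their separate shares cannot be told apart. As far as these compounds go, whether a plain amine or a longer carbon chain at this place would shift the number stays open.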